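The compounds below may be only part of what the source reports. "The series", "measured", "known", "first", "only" and "open" are said of these compounds alone.

Measured so far:
compound 1 `CC(C)C(=O)OCOC(=O)C1=C(S[C@@H]2CN[C@H](C(=O)Nc3cccc(C(=O)OCOC(=O)C(C)C)c3)C2)[C@H](C)[C@@H]2[C@@H]([C@@H](C)O)C(=O)N12` — > 95%
compound 2 `CCOC(=O)C1=C(S[C@H]2C[C@@H](C(=O)Nc3cccc(C(=O)OCC)c3)N(C(=O)OCc3oc(=O)oc3C)C2)[C@H](C)[C@@H]2[C@@H]([C@@H](C)O)C(=O)N12` — > 95%

In an ADME assay for metabolic stability, read by LC-MS, with a stated time of 3 h, at pH 6.5, tested at 50 uM (a higher number here means that more of the compound is left, a lower number that less of the compound is left), compound 1 gives > 95%, which is a limit of the assay and not a number. Compound 2 gives > 95% in this assay, again a limit. Compound 1 therefore stands at the limit of > 95% in this assay, at which 2 of the 2 values shown sit, so no finer placement among the shown values is possible. Compound 3 `CC(C)C(=O)OCOC(=O)c1cccc(NC(=O)[C@@H]2C[C@H](SC3=C(C(=O)O)N4C(=O)[C@H]([C@@H](C)O)[C@H]4[C@H]3C)CN2)c1` has not yet been measured in this assay. It differs from compound 1 by hydrogen in place of ((isopropylcarbonyl)oxy)methyl on an oxygen next to a carbonyl group. For the measured compounds named here, no step between two measured compounds exists that would show how such a change moves the read-out, so the expectation rests only on where compound 1 sits and on the change itself. The step from compound 1 to compound 3 is expected to be a modest loss, possibly none beyond the scatter, a number at least 7 percentage points lower from compound 1 to compound 3 (that floor lies within the scatter). Compound 3 is therefore estimated at 88%, with a range from 65% to 98%.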

Compound 3, percent of the compound remaining: > 95%
Compound 3: only a limit was reported (the forecaster's own chance of this, stated with the estimate: 40%); middle value at least 7 percentage points away from the limit.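

For the compounds shown here, compound 1 and compound 3 both sit at a limit of the assay and not at a number, so no step between them can be read: the limit of > 95% in this assay, at which 3 of the 3 values shown sit. The compounds shown leave open whether hydrogen in place of ((isopropylcarbonyl)oxy)methyl on an oxygen next to a carbonyl group changes the percent of compound remaining at all, and by how much.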